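Compound 3: 4-chlorophenyl in place of 3-hydroxyphenyl

The compounds below may be only part of what the source reports. "The series", "measured", "known", "first", "only" and "open" are said of these compounds alone.

Compound 1 `COc1ccc(-c2nc3cnccn3c2Nc2cc(OC)c(OC)c(OC)c2)cc1O`: 38000 nM
Compound 2 `COc1cc(Nc2c(-c3cccc(O)c3)nc3cnccn23)cc(OC)c1OC`: 42000 nM

Among the compounds with values here, in a functional assay on HEK-293T cells (Homo sapiens) for cytotoxicity, read by MTT assay (a higher number here means that more compound is tolerated, a lower number that less compound is tolerated), compound 2 gives 42000 nM as one of only two numbers so far, and it lies within the scatter of compound 1. The next compound to be measured is compound 3 `COc1cc(Nc2c(-c3ccc(Cl)cc3)nc3cnccn23)cc(OC)c1OC` which carries 4-chlorophenyl in place of 3-hydroxyphenyl on an aromatic carbon of the shared core (4-chlorophenyl in place of 3-hydroxyphenyl on an aromatic carbon) and is otherwise the same as compound 2. Within the data shown here, the one measured step is a different change, hydrogen in place of methoxy on an aromatic carbon. Among the measured compounds shown here, with only a 1.1-fold higher number from compound 1 to compound 2 (0.04 log units; within the scatter) as a guide and no measured compound carrying 4-chlorophenyl, no shift beyond the scatter is expected in either direction. The expected step is a 1.2-fold lower number from compound 2 to compound 3 (0.08 log units; within the scatter) in this assay and remains a weakly supported estimate. For compound 3 the estimated value is 35000 nM with an expected range of 12000 nM to 90000 nM for the coming measurement.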

Compound 3, concentration lethal to 50% of the cells: 25000 nM
The estimate for compound 3 lay 1.4-fold (0.15 log units) above the measured number; the range from low to high includes it.
By their numbers in this assay, from the lowest: compounds 3, 1 and 2 (each within the scatter of the next).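

In this assay the earlier step touched only a methoxy group on the phenyl ring, whereas here the ring's substitution is replaced outright at this aromatic carbon of the five-membered ring. 4-chlorophenyl in place of 3-hydroxyphenyl gives a 1.7-fold lower number from compound 2 to compound 3 (0.23 log units; within the scatter) and 4-chlorophenyl in place of 3-hydroxy-4-methoxyphenyl gives a 1.5-fold lower number from compound 1 to compound 3 (0.18 log units; within the scatter) so, in these compounds, exchanging the hydroxy-bearing phenyl for one with chlorine and no hydrogen-bond donor leaves the number within the scatter. Nothing available accounts for these small steps.

The compounds shown leave open whether an amine or a carboxylic acid on this phenyl ring would take the number beyond the scatter. They also leave open how the chlorine and the loss of the hydroxy group each contribute, as both differences arrive together.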